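A few compounds are considered here, and "the series" means these few. Any claim that something is new, unique, unknown or untested is made for them only; others in the source may bear on it.

Compound 1 `CC1(C)O[C@H]([C@H]2COC(C)(C)O2)[C@@H](C2CC(=O)SS2)O1` and compound 2 `CC1(C)O[C@H]([C@H]2COC(C)(C)O2)[C@@H](C2CC(=O)S[S+]2[O-])O1` share one core. In a functional assay on HeLa cells (Homo sapiens) for cytotoxicity, read by MTT assay, in the presence of a further agent that is not named here (on this read-out higher numbers stand for weaker inhibition and lower numbers for stronger inhibition), compound 1 gives 16900 nM. Compound 2 carries the change (a group of 7 heavy atoms (3 carbon, 2 oxygen, 2 sulfur; one five-membered non-aromatic ring with 2 hetero atoms) in place of a group of 6 heavy atoms (3 carbon, 1 oxygen, 2 sulfur; one five-membered non-aromatic ring with 2 hetero atoms), on a saturated ring carbon), and in this assay compound 2 gives 12600 nM. For the measured compounds named here, the step of a 1.3-fold lower number from compound 1 to compound 2 (0.13 log units; within the scatter) is the only measured example of this change. Compound 3 `Cc1cn([C@H]2C[C@H](O[Si](C)(C)C(C)(C)C)[C@@H](C3CC(=O)SS3)O2)c(=O)[nH]c1=O` is built on another core; how that core differs from the core of compound 1 is not broken down here. In this assay compound 3 gives 16700 nM, a value within the scatter of both compound 1 and compound 2, so no order among the three is claimed.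

Compound 4 `Cc1cn([C@H]2C[C@H](O[Si](C)(C)C(C)(C)C)[C@@H](C3CC(=O)S[S+]3[O-])O2)c(=O)[nH]c1=O` has not yet been measured. It differs from compound 3 by a group of 7 heavy atoms (3 carbon, 2 oxygen, 2 sulfur; one five-membered non-aromatic ring with 2 hetero atoms) in place of a group of 6 heavy atoms (3 carbon, 1 oxygen, 2 sulfur; one five-membered non-aromatic ring with 2 hetero atoms), on a saturated ring carbon. This is the same kind of change as from compound 1 to compound 2, but the surroundings differ: in compound 1 the place is on a saturated ring carbon of a five-membered non-aromatic ring with 2 oxygen, next to the ring oxygen, next to the ring atom that bears a group of 7 heavy atoms, two ring bonds from the ring oxygen and two ring bonds from the ring atom that bears two methyl groups; in compound 3 it is on a saturated ring carbon of a five-membered non-aromatic ring with 1 oxygen, next to the ring oxygen. Because a 1.3-fold lower number from compound 1 to compound 2 (0.13 log units; within the scatter) stayed within the scatter, the expected step in this assay is a 1.3-fold lower number from compound 3 to compound 4 (0.11 log units; within the scatter). On that basis compound 4 is expected to give 13000 nM in this assay, with an expected range from 6500 nM to 26000 nM.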

Compound 4, half-maximal inhibitory concentration: 6610 nM
For compound 4 the middle estimate is 2.0-fold (0.29 log units) above the measured one; the measured number falls inside the stated range.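

In this assay, putting the group of 7 heavy atoms in place of the group of 6 heavy atoms on the core of compound 3 gives a 2.5-fold lower number from compound 3 to compound 4 (0.40 log units; beyond the scatter), a modest step that stands beyond the scatter, unlike the earlier step on the core of compound 1. Even so, the two steps cannot be told apart, and the change cannot be said to act differently on the two cores: the same change on two cores in this assay, a 1.3-fold lower number (0.13 log units; within the scatter) from compound 1 to compound 2 and a 2.5-fold lower number (0.40 log units; beyond the scatter) from compound 3 to compound 4, 1.9-fold (0.27 log units) apart, within the scatter of two such steps. This shows that the earlier step gave no sign of a clear gap between the cores, and that a lower number beyond the scatter was seen on the core of compound 3 only; it does not show that the change has one fixed size across the series, as two pairs of compounds are too few to show that.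

The compounds shown leave open whether the same change would give a similar step on a core that carries an amine, a carboxylic acid or a longer alkyl chain. They also leave open how the group of 6 heavy atoms would compare with a related five-membered ring that holds a nitrogen atom in place of one sulfur atom.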